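The source may report more compounds than this note shows. Statements on the series, on what has been measured and on what is new or still open speak of the compounds shown alone.

Three compounds built on a shared core were tested in an ADME assay on MT4 cells (Homo sapiens) for cytotoxicity, read by MTT assay, with a stated time of 5 days; on this read-out higher numbers stand for lower toxicity in this test and lower numbers for higher toxicity in this test. Compound 1 `Cc1cccc(C)c1Oc1cc(Nc2ccc(C#N)cc2)[nH]c(=O)c1Cl` gives 29000 nM, compound 3 `Cc1cc(C#N)cc(C)c1Oc1cc(Nc2ccc(C#N)cc2)[nH]c(=O)c1` gives 25000 nM, and compound 2 `COc1cc(Oc2c(C)cccc2C)cc(Nc2ccc(C#N)cc2)n1` gives 8500 nM, the lowest of the three numbers; its gaps to compound 3 and to compound 1 both lie beyond the scatter. From compound 2 the account moves to compound 4 `COc1cc(Oc2c(C)cc(C)cc2C)cc(Nc2ccc(C#N)cc2)n1`, which differs by methyl in place of hydrogen on an aromatic carbon. Going by the values given here, no measured pair shows what this change does, so the size of the step in this assay cannot be read from the numbers at hand. The step from compound 2 to compound 4 is therefore expected to stay within the scatter, or at most to move slightly toward a lower number. Compound 4 is expected to give about 7000 nM in this assay, with a range from 3000 nM to 17000 nM. The expected step this implies is a 1.2-fold lower number from compound 2 to compound 4 (0.08 log units; within the scatter).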

Compound 4, half-maximal cytotoxic concentration: 29000 nM
For compound 4 the middle estimate is 4.1-fold (0.62 log units) below the measured one; measured number outside the range, above it.
By their numbers in this assay, from the lowest: compound 2; then compounds 3, 1 and 4 (each within the scatter of the next).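

Going by these compounds alone, this step gives the first measured reading at this position: going from 2,6-dimethylphenyl to 2,4,6-trimethylphenyl yields a 3.4-fold higher number from compound 2 to compound 4 (0.53 log units; beyond the scatter) in this assay and so moves the read-out toward lower toxicity in this test. A single methyl para to the large group is thus enough to shift the number beyond the scatter. Nothing at hand explains this shift. On these data alone, whether an ethyl group or an amine in place of this methyl would shift the number further stays open. So does whether the same methyl would act alike on the core of compound 1.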